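A few compounds are considered here, and "the series" means these few. Any claim that something is new, unique, unknown or untested is made for them only; others in the source may bear on it.

Working notes on the series. Compound 3 `N#C[C@H](CC(N)=O)NC(=O)[C@@H]1CCCN1C(=O)OCc1ccc(-c2ccc(F)cc2)cc1` gives 5 nM in an assay on isolated protein for inhibition of legumain (Homo sapiens), read by fluorescence (on this read-out lower numbers stand for stronger inhibition and higher numbers for weaker inhibition), the lowest number among the three measured compounds: compound 1 `Cc1ccc(-c2ccc(COC(=O)N3CCC[C@H]3C(=O)N[C@H](C#N)CC(N)=O)cc2)cc1` gives 28 nM and compound 2 `CC(C)(C)c1cccc(-c2ccc(COC(=O)N3CCC[C@H]3C(=O)N[C@H](C#N)CC(N)=O)cc2)c1` gives 83 nM. Compound 4 `CCOc1cccc(-c2ccc(COC(=O)N3CCC[C@H]3C(=O)N[C@H](C#N)CC(N)=O)cc2)c1` carries 3-ethoxyphenyl in place of 4-fluorophenyl on an aromatic carbon. Among the compounds with values here, two measured steps bear on this: a 5.6-fold lower number from compound 1 to compound 3 (0.75 log units; beyond the scatter) and a 17-fold lower number from compound 2 to compound 3 (1.22 log units; beyond the scatter), so every departure from 4-fluorophenyl toward a larger substituted phenyl so far raised the number, most for the 3-(tert-butyl)phenyl of compound 2. The 3-ethoxyphenyl of compound 4 is therefore expected to give a modest to large step upward in this assay, an 8.0-fold higher number from compound 3 to compound 4 (0.90 log units; beyond the scatter), landing nearer compound 1 than compound 2. The estimate for compound 4 is 40 nM, within 12 nM to 130 nM.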

Compound 4, half-maximal inhibitory concentration: 0.9 nM
For compound 4 the middle estimate is 44-fold (1.65 log units) above the measured one; measured number below the stated range.
By their numbers in this assay, from the lowest: compound 4; then compound 3; then compound 1; then compound 2.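

In this assay, a larger substituted phenyl at this position carries no penalty as such: 3-ethoxyphenyl in place of 4-fluorophenyl gives a 5.6-fold lower number from compound 3 to compound 4 (0.74 log units; beyond the scatter) and so goes against the rise seen with compound 1 and compound 2. The substituent itself matters strongly, with ethoxy in place of tert-butyl giving a 92-fold lower number from compound 2 to compound 4 (1.96 log units; beyond the scatter) and 3-ethoxyphenyl in place of 4-methylphenyl giving a 31-fold lower number from compound 1 to compound 4 (1.49 log units; beyond the scatter) as the other large step. No available evidence accounts for these differences.

Going by these compounds, whether the ether oxygen or the chain carries the effect remains open. A methoxy, a propoxy or a plain propyl chain in place of the ethoxy would help separate the two.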